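The compounds below may be only part of what the source reports. "The series", "measured", "known", "first", "only" and "open" are said of these compounds alone.

Compound 2 `COc1cc(OC)cc(C(=O)Nc2cccc(-c3oc4cc(-c5ccc(F)cc5)ccc4c(=O)c3O)c2)c1` and compound 1 `O=C(Nc1cccc(-c2oc3cc(-c4ccc(F)cc4)ccc3c(=O)c2O)c1)c1ccc(F)cc1F` share a core and differ only in the aryl group attached to the amide carbonyl carbon. In a functional assay on HepG2 cells (Homo sapiens) for antiproliferative activity, read by CCK-8 assay, with a stated time of 72 h (a lower number here means a stronger inhibitor, a higher number a weaker inhibitor), compound 1 gives 26400 nM, and in the same assay compound 2 gives 23500 nM. Within the data shown here, of the two numbers so far, compound 2 has the lower one, but its only neighbour, compound 1, sits within the scatter of it, so the two cannot be told apart. Among the measured compounds shown here, the one measured step, a 1.1-fold lower number from compound 1 to compound 2 (0.05 log units; within the scatter), shows that exchanging one aryl group for another at this carbonyl carbon left the read-out essentially unchanged.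

Compound 3 `O=C(Nc1cccc(-c2oc3cc(-c4ccc(F)cc4)ccc3c(=O)c2O)c1)c1ccc(Cl)nc1` continues at the same place: 6-chloropyridin-3-yl in place of 3,5-dimethoxyphenyl on a carbonyl carbon. For the measured compounds named here, since the only step that bears on this position, from compound 1 to compound 2, lay within the scatter, a change of the same kind is expected to do much the same, and the step from compound 2 to compound 3 is estimated as a 1.0-fold higher number from compound 2 to compound 3 (0.01 log units; within the scatter). Compound 3 is therefore expected to give 24000 nM in this assay, with a range from 10000 nM to 55000 nM.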

Compound 3, half-maximal inhibitory concentration: 4610 nM
Beside the measured number, compound 3's estimate is 5.2-fold (0.72 log units) above it; the measured number lies below the stated range.
By their numbers in this assay, from the lowest: compound 3; then compounds 2 and 1 (each within the scatter of the next).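

The position on the amide carbonyl carbon turns out not to be indifferent to the aryl group, as the first pair suggested: in this assay, compound 1 and compound 2 lie within the scatter of each other (a 1.1-fold lower number from compound 1 to compound 2 (0.05 log units; within the scatter)), yet 6-chloropyridin-3-yl in place of 3,5-dimethoxyphenyl gives a step beyond it (a 5.1-fold lower number from compound 2 to compound 3 (0.71 log units; beyond the scatter)). The same group in place of 2,4-difluorophenyl gives a step of similar standing (a 5.7-fold lower number from compound 1 to compound 3 (0.76 log units; beyond the scatter)), so compound 3 has the lowest number of the three, with its steps to both others printed as beyond the scatter. No supporting measurement bears on why this exchange lowers the number.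

What the compounds shown leave open is which part of the entering group carries the step, since the ring nitrogen and the chlorine arrive together and a plain pyridin-3-yl or a 4-chlorophenyl group would be needed to separate them. On these data alone, it also remains open whether the chlorine could give way to a methoxy group or an amine on the same ring with the read-out kept at the level of compound 3.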